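Swapping a Pyrrolidine for a Fused Bicyclic Amine

The source may report more compounds than this note shows. Statements on the series, on what has been measured and on what is new or still open speak of the compounds shown alone.

Compound 2 `CN(C)[C@H]1CCN(c2cccc3c2C[C@H](CN(C)[C@H]2CCCc4cccnc42)NC3)C1` is one of three compounds tested in a functional assay on CCRF-CEM cells for antagonist activity at C-X-C chemokine receptor type 4 (Homo sapiens), read by calcium flux, with stated times of 25 min and 90 s; a lower number here means a stronger inhibitor, a higher number a weaker inhibitor. In this assay compound 2 gives 10.9 nM, the second highest of the three numbers. Compound 1 `CN(C[C@H]1Cc2c(cccc2N2C[C@H]3CNC[C@H]3C2)CN1)[C@H]1CCCc2cccnc21` gives 10.3 nM. The step of a 1.1-fold higher number from compound 1 to compound 2 (0.02 log units; within the scatter) was within the scatter. Among the compounds with values here, compound 3 `CN1CCN(Nc2cccc3c2C[C@@H](CN(C)[C@H]2CCCc4cccnc42)NC3)CC1` gives 47.4 nM, a higher number than compound 2 and beyond the scatter; no single-place step links these two, so only their values can be set side by side.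

Compound 4 `CN1CC[C@H]2CN(c3cccc4c3C[C@H](CN(C)[C@H]3CCCc5cccnc53)NC4)C[C@H]21` differs from compound 2 in one place: a group of 9 heavy atoms (7 carbon, 2 nitrogen; 2 five-membered non-aromatic rings with 1 hetero atom each) in place of a group of 8 heavy atoms (6 carbon, 2 nitrogen; one five-membered non-aromatic ring with 1 hetero atom), on an aromatic carbon. Within the data shown here, the only measured step that bears on this is the one from compound 1 to compound 2, which exchanged a group with two five-membered rings for a group with one five-membered ring on an aromatic carbon, and that step stayed within the scatter. Compound 4 brings back a group with two five-membered rings at that position, so the expected step of a 1.0-fold higher number from compound 2 to compound 4 (0.00 log units; within the scatter) is none beyond the scatter. Compound 4 is therefore estimated at 11 nM, with a range from 5 nM to 25 nM.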

Compound 4, half-maximal inhibitory concentration: 11.4 nM
For compound 4 the middle estimate is 1.0-fold (0.02 log units) below the measured one, and the stated range covers the measured number.
By their numbers in this assay, from the lowest: compounds 1, 2 and 4 (each within the scatter of the next); then compound 3.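

On this aromatic carbon, replacing the 3-(dimethylamino)pyrrolidin-1-yl group with the group holding two five-membered rings and one more defined stereocentre gives a 1.0-fold higher number from compound 2 to compound 4 (0.02 log units; within the scatter) in this assay, so the second ring can be added here with no change beyond the scatter. Exchanging one two-ring group for another gives a 1.1-fold higher number from compound 1 to compound 4 (0.04 log units; within the scatter), which means that the three groups now seen at this place cannot be told apart by this read-out. No measured data explain why these values stay so close to each other.

From the compounds shown here alone, all three groups are cyclic amines, so it remains open how an open-chain group such as dimethylamino, a longer aminoethyl chain or a carboxylic acid would read here. Also open, going by these compounds, is how the mirror-image form of the two-ring group would read.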